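Tetrahydroquinoline amide next in the nitrobenzamide series

The compounds below may be only part of what the source reports. "The series", "measured", "known", "first", "only" and "open" are said of these compounds alone.

Measured so far:
Compound 1 `CS(=O)(=O)c1ccc(C(=O)N2CCC(C(=O)N3CCN(c4ccc(F)cc4)CC3)CC2)cc1[N+](=O)[O-]` gives > 60000 nM in an assay on isolated protein for inhibition of thyroid hormone receptor beta (Homo sapiens), read by fluorescence polarization; a higher number here means a weaker inhibitor, a lower number a stronger inhibitor; this is a limit of the assay.
Compound 2 `CN(Cc1cccc(F)c1)C(=O)CCCNC(=O)c1ccc(S(C)(=O)=O)c([N+](=O)[O-])c1` gives > 60000 nM in this assay; this is a limit of the assay.
Compound 3 `CS(=O)(=O)c1ccc(C(=O)NCCC(=O)N2CCCCC2)cc1[N+](=O)[O-]` gives > 60000 nM in this assay; this is a limit of the assay.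

Among the compounds with values here, compound 3 thus stands where the other two stand, at the limit of > 60000 nM in this assay, at which 3 of the 3 values shown sit; no number separates any of the three, and no step between measured compounds can be drawn from them.

Compound 4 `CS(=O)(=O)c1ccc(C(=O)NCCC(=O)N2CCCc3ccccc32)cc1[N+](=O)[O-]` differs from compound 3 in one place: 1,2,3,4-tetrahydroquinolin-1-yl in place of piperidin-1-yl on a carbonyl carbon. Within the data shown here, with every measured value of the series sitting at a limit, there is no measured step to anchor an expectation of direction or size in this assay; the expected outcome is a further limit rather than a step beyond the scatter. The expected step that the limit leaves unreadable from compound 3 to compound 4 therefore rests on the estimate alone. Compound 4 is expected to give about 100000 nM, in the range 30000 nM to 400000 nM, most likely reported again as a limit.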

Compound 4, half-maximal inhibitory concentration: > 60000 nM
Compound 4 gave a limit, no number; the forecaster's own chance of this, stated with the estimate: 85%; the middle value lies beyond the limit too.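

No step can be read from compound 3 to compound 4, since both give only a limit in this assay: the limit of > 60000 nM in this assay, at which 4 of the 4 values shown sit. The compounds shown leave open whether any member of this series reaches a measurable inhibition in this assay.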